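Chain lengthening across two aryl variants

The source may report more compounds than this note shows. Statements on the series, on what has been measured and on what is new or still open speak of the compounds shown alone.

Compound 1 `CCCCCCCCNC(=O)[C@@H]1CSC(c2cc(OC)c(OC)c(OC)c2)N1` gives 20800 nM in an ADME assay on cells (Fibroblast, Homo sapiens) for antiproliferative activity, read by sulforhodamine B assay, with a stated time of 48 h; a lower number here means a stronger inhibitor, a higher number a weaker inhibitor. Compound 2 `CCCCCCCCCCCCNC(=O)[C@@H]1CSC(c2cc(OC)c(OC)c(OC)c2)N1` differs from it by butyl in place of hydrogen on a saturated chain carbon, eight bonds along the chain from an amide-type nitrogen and gives 2400 nM; the step is an 8.7-fold lower number from compound 1 to compound 2 (0.94 log units; beyond the scatter). Compound 3 `CCCCCCCCCCCCNC(=O)[C@@H]1CSC(c2ccc(N)cc2)N1` carries another core; the difference between the cores of compound 1 and compound 3 is not broken down here. In this assay compound 3 gives 4100 nM, within the scatter of compound 2. Compound 4 `CCCCCCCCCCCCCCCCNC(=O)[C@@H]1CSC(c2ccc(N)cc2)N1` is not yet measured and differs from compound 3 by butyl in place of hydrogen on a saturated chain carbon, ten or more bonds along the chain from an amide-type nitrogen. This is the same kind of change as from compound 1 to compound 2, though the place along the chain, as given in the two differences, is not the same word for word. Because the earlier step was an 8.7-fold lower number from compound 1 to compound 2 (0.94 log units; beyond the scatter), a lower number is expected for compound 4. The two cores differ and the place is not the same word for word, so a smaller expected step is assumed, a 3.4-fold lower number from compound 3 to compound 4 (0.53 log units; beyond the scatter). Compound 4 is estimated at 1200 nM, between 500 nM and 3000 nM.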

Compound 4, half-maximal inhibitory concentration: 7400 nM
Compound 4: middle estimate off by 6.2-fold (0.79 log units), on the low side, and the stated range ends below it.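

In this assay the change of hydrogen to butyl on the chain does not carry from one core to the other in this series: the same change on two cores in this assay, an 8.7-fold lower number (0.94 log units; beyond the scatter) from compound 1 to compound 2 and a 1.8-fold higher number (0.26 log units; within the scatter) from compound 3 to compound 4, 16-fold (1.19 log units) apart, beyond the scatter of two such steps. For the compounds shown here, on the core of compound 3 the step reads a 1.8-fold higher number from compound 3 to compound 4 (0.26 log units; within the scatter), so the lower number seen on the core of compound 1 has no counterpart there. Core and place on the chain are not separated here: the two steps also differ in place, and each core offers a single pair.

Open, from the compounds shown here alone, are the longer chain of compound 4 on the core of compound 1 and the shorter chain of compound 1 on the core of compound 3. Also open, going by these compounds, is how a chain ending in a carboxylic acid or an amine reads in this assay.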